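The source may hold more compounds than are shown below. What is called first, only, known or untested is meant among the compounds shown, and "the series" means these compounds.

Measured so far:
- compound 1 `CCn1c(C(=O)NCC(OC)OC)ccc1C(CC)(CC)c1ccc(OCC(O)C(C)(C)C)c(C)c1`: > 50000 nM
- compound 2 `C#CC(C)OC(=O)c1ccc(C(CC)(CC)c2ccc(OCC(O)C(C)(C)C)c(C)c2)n1CC`: > 50000 nM

The test here is a functional assay on MCF7 cells (Homo sapiens), read by MTT assay, with a stated time of 48 h; a higher number here means a weaker inhibitor, a lower number a stronger inhibitor. In this test compound 2 gives > 50000 nM, and this is a limit of the assay and not a number. Compound 1 gives > 50000 nM, which is a limit too. So compound 2 has no exact position, and the same is true of the only other compound tested.

The next compound is compound 3 `CCn1c(C(=O)N(C)CC(=O)O)ccc1C(CC)(CC)c1ccc(OCC(O)C(C)(C)C)c(C)c1`. It keeps the shared core and replaces one group on a carbonyl carbon, (carboxymethyl)(methyl)amino in place of (1-methylprop-2-yn-1-yl)oxy on a carbonyl carbon.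

Among the compounds with values here, only one measured step bears on this change, since it alters the group on the same carbonyl carbon: a step that the two limits leave unreadable from compound 1 to compound 2. Its size cannot be read, so it offers no direction or size to carry over. Both compound 1 and compound 2 sit at the same limit: the limit of > 50000 nM in this assay, at which 2 of the 2 values shown sit. On that basis, compound 3 is expected to stay at or near this limit too, with no measurable gain in strength.

The expected step is a number no higher from compound 2 to compound 3 (the limit leaves the size open).

For compound 3 the estimated value is 50000 nM, with an expected range from 20000 nM to 120000 nM.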

Compound 3, half-maximal inhibitory concentration: 25400 nM
Compound 3: the middle estimate sits 2.0-fold (0.29 log units) above what was measured, and the stated range covers the measured number.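

In this assay, within the data shown here, compound 3 gives 25400 nM, the first exact number for a group on this carbonyl carbon. The other readings are limits of the assay and not numbers: the limit of > 50000 nM in this assay, at which 2 of the 3 values shown sit. Putting (carboxymethyl)(methyl)amino in place of (1-methylprop-2-yn-1-yl)oxy gives an at least 1.9-fold lower number from compound 2 to compound 3 (0.29 log units; that floor lies within the scatter), and putting it in place of (2,2-dimethoxyethyl)amino gives an at least 1.9-fold lower number from compound 1 to compound 3 (0.29 log units; that floor lies within the scatter). Both steps are only floors, and each floor lies within the usual scatter, so this change brings a measured number at this position but does not yet establish a real gain in strength, although the true gaps could be larger.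

The compounds shown leave open which part of the (carboxymethyl)(methyl)amino group goes with the measured number, a question that a methyl ester of the same acid or a plain dimethylamino group on the carbonyl carbon could help to answer. Also open, as far as these compounds go, is whether a longer chain ending in the carboxylic acid, or an amine at the end of the chain in its place, would shift the number further.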